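A Second Methoxy on Compound 3

This account rests on a few compounds, and the source may have more. Where it says the series, first, only, none or still open, it means among the compounds named here.

Three compounds sharing one core have numbers in a functional assay on MCF7 cells (Homo sapiens) for inhibition, read by MTT assay, with a stated time of 48 h; on this read-out higher numbers stand for weaker inhibition and lower numbers for stronger inhibition. Compound 1 `Brc1ccc2[nH]cc(C(c3ccccc3)c3c[nH]c4ccc(Br)cc34)c2c1` gives 5500 nM, compound 2 `Oc1ccc(C(c2c[nH]c3ccc(Br)cc23)c2c[nH]c3ccc(Br)cc23)cc1` gives 3500 nM, and compound 3 `COc1ccc(C(c2c[nH]c3ccc(Br)cc23)c2c[nH]c3ccc(Br)cc23)cc1` gives 2300 nM. Among the measured compounds shown here, compound 3 stands clear of only one neighbour. The data show a 2.4-fold lower number from compound 1 to compound 3 (0.38 log units; beyond the scatter), a modest gap, but also a 1.5-fold lower number from compound 2 to compound 3 (0.18 log units; within the scatter), so those two cannot be told apart.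

Compound 4 `COc1ccc(C(c2c[nH]c3ccc(Br)cc23)c2c[nH]c3ccc(Br)cc23)c(OC)c1` goes from 4-methoxyphenyl to 2,4-dimethoxyphenyl: methoxy in place of hydrogen on an aromatic carbon. The new methoxy sits on an aromatic carbon, ortho to a large group and meta to a methoxy group.

The closest measured precedent is a 2.4-fold lower number from compound 1 to compound 3 (0.38 log units; beyond the scatter), where a methoxy also replaced hydrogen on an aromatic carbon. The related hydroxy change gave a 1.6-fold lower number from compound 1 to compound 2 (0.20 log units; within the scatter). For the measured compounds named here, both changes were made on a ring that carried no other group, and no measured compound has a group at the new position, so the precedent is only a loose guide. A small step towards a lower number in this assay is expected, probably too small to rise above the scatter. The expected change is a 1.2-fold lower number from compound 3 to compound 4 (0.06 log units; within the scatter). In this assay, the estimated value for compound 4 is 2000 nM, with an expected range from 800 nM to 5000 nM.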

Compound 4, half-maximal inhibitory concentration: 77500 nM
Estimate against measurement, compound 4: 39-fold (1.59 log units) below; measured number above the stated range.
By their numbers in this assay, from the lowest: compounds 3, 2 and 1 (each within the scatter of the next, the first and the last beyond it); then compound 4.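

Methoxy in place of hydrogen on this aromatic carbon, ortho to a large group and meta to a methoxy group, gives in this assay a 34-fold higher number from compound 3 to compound 4 (1.53 log units; beyond the scatter) and so moves the number the opposite way from the earlier methoxy step, a 2.4-fold lower number from compound 1 to compound 3 (0.38 log units; beyond the scatter); at least in these compounds, the same small group does not have the same outcome at each place on the ring. The 2,4-dimethoxyphenyl compound also stands well apart from the two compounds with simpler rings, with a 22-fold higher number from compound 2 to compound 4 (1.35 log units; beyond the scatter) and a 14-fold higher number from compound 1 to compound 4 (1.15 log units; beyond the scatter), which makes compound 4 the weakest of the four in this read-out. Nothing measured here accounts for this jump.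

On these data alone, whether any group at this position would raise the number so far, or whether this is particular to methoxy, stays open, and a fluorine or an amine there would help to separate the two. Also open, as far as these compounds go, is whether the new methoxy would have the same outcome on a ring carrying no other group.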